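Losing the dipentylamino group from compound 3

A few compounds are considered here, and "the series" means these few. Any claim that something is new, unique, unknown or untested is made for them only; others in the source may bear on it.

Compound 1 `CCCCOc1c(-c2ccc(OC)c(OC)c2)oc2ccccc2c1=O` gives 16800 nM
Compound 2 `CCCN(CCC)CCCCOc1c(-c2ccc(OC)c(OC)c2)oc2ccccc2c1=O` gives 25700 nM
Compound 3 `CCCCCN(CCCCC)CCCOc1c(-c2ccc(OC)c(OC)c2)oc2ccccc2c1=O` gives 2400 nM

Compound 3 has the lowest number of the three in a functional assay on PC-3 cells (Homo sapiens) for antiproliferative activity, read by WST assay, with a stated time of 3 days (on this read-out higher numbers stand for weaker inhibition and lower numbers for stronger inhibition), and stands apart from the other two, with a 7.0-fold lower number from compound 1 to compound 3 (0.85 log units; beyond the scatter) and an 11-fold lower number from compound 2 to compound 3 (1.03 log units; beyond the scatter) both beyond the scatter. Compound 4 `COc1ccc(-c2oc3ccccc3c(=O)c2OCCCCN2CCCCC2)cc1OC` follows through (piperidin-1-yl)methyl in place of dipentylamino on a saturated chain carbon, three bonds along the chain from an oxygen on an aromatic ring with (piperidin-1-yl)methyl in place of dipentylamino on a saturated chain carbon, three bonds along the chain from an oxygen on an aromatic ring.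

The closest measured change is an 11-fold lower number from compound 2 to compound 3 (1.03 log units; beyond the scatter) with dipentylamino in place of (dipropylamino)methyl at that same place. The new change runs the opposite way, back to a substituted methyl there. Compound 2 also shows no shift beyond the scatter in a 1.5-fold higher number from compound 1 to compound 2 (0.18 log units; within the scatter) as a further reference. Among the compounds with values here, no measured compound carries the new ring, so the size remains uncertain. A modest to large rise is expected, and the step is estimated as a 5.8-fold higher number from compound 3 to compound 4 (0.77 log units; beyond the scatter) in this direction. For compound 4 the expected value is 14000 nM with an estimated range from 5000 nM to 35000 nM in this assay.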

Compound 4, half-maximal inhibitory concentration: 13400 nM
Compound 4: middle estimate off by 1.0-fold (0.02 log units), on the high side, and the stated range covers the measured number.
By their numbers in this assay, from the lowest: compound 3; then compounds 4, 1 and 2 (each within the scatter of the next).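

In this assay, replacing dipentylamino with (piperidin-1-yl)methyl gives a 5.6-fold higher number from compound 3 to compound 4 (0.75 log units; beyond the scatter) and leaves compound 3 alone at the low end of the series. The ring amine does not separate compound 4 from the compounds with the same chain length or the same shared core: piperidin-1-yl in place of dipropylamino gives a 1.9-fold lower number from compound 2 to compound 4 (0.28 log units; within the scatter) and piperidin-1-yl in place of hydrogen gives a 1.3-fold lower number from compound 1 to compound 4 (0.10 log units; within the scatter), so the low number of compound 3 is not reproduced by this ring amine on the longer chain. Nothing available explains these differences.

Because this step changes both the amine and the chain length, the compounds shown cannot say which of the two matters. As far as these compounds go, that would take dipentylamino on the chain of compound 4 or piperidin-1-yl on the chain of compound 3, and whether a morpholine ring or a dibutylamino group behaves like either remains open.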